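The source may hold more compounds than are shown below. What is called first, only, known or untested is meant among the compounds shown, and "the series" means these compounds.

- Compound 1 `O=C(CN1CCN(c2nnc(Cc3ccccc3)c3ccccc23)CC1)Nc1ccc(F)c(C(F)(F)F)c1`: 2480 nM
- Compound 2 `Cc1ccccc1NC(=O)CN1CCN(c2nnc(Cc3ccccc3)c3ccccc23)CC1`: "not active" (no number reported)
- Compound 3 `O=C(CN1CCN(c2nnc(Cc3ccccc3)c3ccccc23)CC1)Nc1cccc(F)c1`: 130000 nM

In a functional assay on A549 cells (Homo sapiens) for cytotoxicity, read by MTT assay, with a stated time of 72 h (on this read-out higher numbers stand for weaker inhibition and lower numbers for stronger inhibition), compound 3 gives 130000 nM, the higher of the two numbers available, so it is the weaker of the two compounds with a number. Compound 4 `Cc1ccc(NC(=O)CN2CCN(c3nnc(Cc4ccccc4)c4ccccc34)CC2)c(C)c1` carries 2,4-dimethylphenyl in place of 3-fluorophenyl on an amide-type nitrogen.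

Among the compounds with values here, only one measured step changes this same place: a 52-fold higher number from compound 1 to compound 3 (1.72 log units; beyond the scatter), a large one. It shows that the number can move far with this group, but it involves a different replacement. Compound 2, which also has a methyl group on this ring, is reported as "not active" (no number reported), so a result without a number is possible.

Since compound 3 already stands at 130000 nM, a moderate move towards a lower number is expected, smaller than that large step: a 2.6-fold lower number from compound 3 to compound 4 (0.41 log units; beyond the scatter). For compound 4, the estimated value is 50000 nM, with an expected range of 8000 nM to 200000 nM.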

Compound 4, half-maximal inhibitory concentration: "not active" (no number reported)
No number was reported for compound 4, and the estimate cannot be compared.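

In this assay, within the data shown here, compound 4 is reported only as "not active", so no step from compound 3 to compound 4 can be read. Nothing measured here accounts for this result. Left open is how 2,4-dimethylphenyl compares in number with 3-fluorophenyl on the amide-type nitrogen.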